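This account rests on a few compounds, and the source may have more. Where it says the series, first, only, none or still open, it means among the compounds named here.

Measured compounds:
compound 1 `O=c1oc2cccnc2n1CN1CCN(c2cccc(Cl)c2)CC1` — 10.5 mg/kg
compound 2 `COc1ccccc1N1CCN(Cn2c(=O)oc3cccnc32)CC1` — > 25 mg/kg
compound 3 `O=c1oc2cccnc2n1CN1CCN(c2ccccc2Cl)CC1` — 22.2 mg/kg

In a functional assay on the whole organism with Mus musculus as the target (a lower number here means that less compound is needed, a higher number that more compound is needed for the effect), compound 3 gives 22.2 mg/kg. For compound 2 the value > 25 mg/kg is a limit of the assay, not a number, as noted by the limit of > 25 mg/kg in this assay, at which 1 of the 3 values shown sits. Of the two plain numbers, the higher one belongs to compound 3; the gap to the other is a 2.1-fold higher number from compound 1 to compound 3 (0.33 log units; beyond the scatter).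

Compound 4 `O=c1oc2cccnc2n1CN1CCN(c2ccc(F)cc2)CC1` differs from compound 3 by 4-fluorophenyl in place of 2-chlorophenyl on an amine nitrogen in a ring. All three known steps touch the same aryl group on the ring nitrogen: a 2.1-fold higher number from compound 1 to compound 3 (0.33 log units; beyond the scatter), an at least 2.3-fold higher number from compound 1 to compound 2 (0.37 log units; beyond the scatter) and an at least 1.1-fold lower number from compound 2 to compound 3 (0.05 log units; that floor lies within the scatter). None of them brings in 4-fluorophenyl, so the step to compound 4 rests on analogy only; the aryl changes seen so far shifted the dose modestly, and a shift of that order, in either direction, is the most that is expected here.

Compound 4 is therefore estimated at 15 mg/kg, with a range from 6 mg/kg to 40 mg/kg, which means an expected step of a 1.5-fold lower number from compound 3 to compound 4 (0.17 log units; within the scatter).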

Compound 4, dose for half-maximal effect: 3.5 mg/kg
Estimate against measurement, compound 4: 4.3-fold (0.63 log units) above; the measured number lies below the stated range.
By their numbers in this assay, from the lowest: compound 4; then compound 1; then compound 3. At a limit, above all of these: compound 2.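

In this assay, compound 4 with its 4-fluorophenyl group needs the least compound of the four, showing that a change of aryl group on this ring nitrogen can lower the dose clearly: a 6.3-fold lower number from compound 3 to compound 4 (0.80 log units; beyond the scatter) and a 3.0-fold lower number from compound 1 to compound 4 (0.48 log units; beyond the scatter). The value of compound 2 is a limit and not a number, so its step gives only a floor, an at least 7.1-fold lower number from compound 2 to compound 4 (0.85 log units; beyond the scatter). That step must be read with this in mind: the limit of > 25 mg/kg in this assay, at which 1 of the 4 values shown sits.

In this step, the halogen and its place on the phenyl ring change together, and the compounds shown do not separate the two. On these data alone, whether 4-chlorophenyl or plain phenyl would match 4-fluorophenyl stays open, as does the effect of a pyridine ring on this nitrogen or a longer chain linking it to the shared core.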